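The source may hold more compounds than are shown below. What is called first, only, known or untested is meant among the compounds shown, and "the series" means these compounds.

In an ADME assay on HepG2 cells (Homo sapiens) for cytotoxicity, read by fluorescence and resazurin assay, with a stated time of 24 h (on this read-out higher numbers stand for lower toxicity in this test and lower numbers for higher toxicity in this test), compound 1 (`COC(=O)c1ccc(-c2nnc(SC3=CS(=O)(=O)c4ccccc43)o2)cc1`) gives 18000 nM, compound 2 (`COc1cccc(-c2nnc(SC3=CS(=O)(=O)c4ccccc43)o2)c1`) gives 20000 nM and compound 3 (`Cc1ccc(-c2nnc(SC3=CS(=O)(=O)c4ccccc43)o2)cc1`) gives 31000 nM. Compound 3 therefore stands within the scatter of both compound 1 and compound 2. Compound 4 (`CC(=O)Nc1ccc(-c2nnc(SC3=CS(=O)(=O)c4ccccc43)o2)cc1`) differs from compound 3 as follows: acetamido in place of methyl on an aromatic carbon. This puts acetamido in place of methyl on an aromatic carbon, para to a large group. Among the compounds with values here, two measured steps bear on this substituent: a 1.7-fold higher number from compound 1 to compound 3 (0.24 log units; within the scatter) and a 1.6-fold higher number from compound 2 to compound 3 (0.19 log units; within the scatter). Within the data shown here, no measured compound carries acetamido, so the precedent is indirect. No step beyond the scatter is expected in this assay. The estimated step is a 1.3-fold lower number from compound 3 to compound 4 (0.11 log units; within the scatter). For compound 4 the expected value is 24000 nM, with an estimated range from 11000 nM to 50000 nM.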

Compound 4, half-maximal cytotoxic concentration: 31000 nM
Estimate against measurement, compound 4: 1.3-fold (0.11 log units) below; the range from low to high includes it.
By their numbers in this assay, from the lowest: compounds 1, 2, 3 and 4 (each within the scatter of the next).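

At this place on the aromatic ring, para to a large group, acetamido brings a hydrogen-bond donor that methyl lacks, yet this assay shows no change at the digits printed from compound 3 to compound 4 (within the scatter). Against the ester, the reading is a 1.7-fold higher number from compound 1 to compound 4 (0.24 log units; within the scatter), so methyl, methoxycarbonyl and acetamido in compounds 3, 1 and 4 all lie within the scatter of one another. Nothing available accounts for this flat reading.

As far as these compounds go, whether a free amine, a carboxylic acid or a longer chain here would give a step beyond the scatter remains open. The compounds shown also leave open whether changes to the shared core would do so.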